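A Fluoro Step From an Unmeasured Starting Point

The source may report more compounds than this note shows. Statements on the series, on what has been measured and on what is new or still open speak of the compounds shown alone.

Among the measured compounds shown here, in an ADME assay on microsomes from liver (Homo sapiens) for metabolic stability, read by LC-MS, using NADPH, with stated times of 5 min and 30 min, tested at 1 uM (on this read-out lower numbers stand for a less stable compound and higher numbers for a more stable compound), compound 1 (`COc1ccc(S(=O)(=O)/C=C/c2ccccn2)cc1`) gives 56% and is the only compound in this small set with a number. Its relative compound 2 (`COc1ccc(S(=O)(=O)/C=C/c2cccnc2)cc1`) offers no such anchor. For compound 2 the entry reads "not determined" (no result reported) and so it has no single number and no place on the scale. Compound 3 (`COc1ccc(S(=O)(=O)/C=C/c2ccc(F)nc2)cc1`) is reached from compound 2 by one structural change: fluoro in place of hydrogen on an aromatic carbon which means fluoro in place of hydrogen on an aromatic carbon, next to the ring nitrogen and para to a large group.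

For the measured compounds named here, no step between measured compounds is available, so the data do not show how far such a replacement moves the result in this assay or in which direction. The expectation is therefore no step beyond the usual scatter, although a shift either way remains possible. Going by the values given here, the only guide is compound 1 with its 56% reading. The estimated value for compound 3 is 55% with an expected range from 30% to 80% as the span of this estimate.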

Compound 3, percent of the compound remaining: 46%
Beside the measured number, compound 3's estimate is 9 percentage points above it; low and high end bracket the measured number.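

In this assay, among the compounds shown here, compound 3 gives 46% but compound 2 has no single number, so no step between compound 2 and compound 3 can be read. The compounds shown leave open how far, and in which direction, fluoro in place of hydrogen moves this read-out. No supporting evidence bears on the result.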